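Nitrophenyl swap from compound 2 to compound 3

A few compounds are considered here, and "the series" means these few. Any claim that something is new, unique, unknown or untested is made for them only; others in the source may bear on it.

Measured so far in a functional assay on A549 cells (Homo sapiens) for cytotoxicity, read by MTT assay, with a stated time of 24 h; a lower number here means a stronger inhibitor, a higher number a weaker inhibitor
- compound 1 `C/C(=N\NC(=O)/C(C#N)=C/c1ccc(N(C)C)cc1)c1c(O)c2ccc(O)cc2oc1=O` gives 4310 nM
- compound 2 `C/C(=N\NC(=O)/C(C#N)=C/c1cccc([N+](=O)[O-])c1)c1c(O)c2ccc(O)cc2oc1=O` gives 21900 nM

Compound 2 holds the higher of the two numbers, and the gap to compound 1 lies beyond the scatter. Next in the series is compound 3 `C/C(=N\NC(=O)/C(C#N)=C/c1ccc([N+](=O)[O-])cc1)c1c(O)c2ccc(O)cc2oc1=O` which has 4-nitrophenyl in place of 3-nitrophenyl on a double-bonded chain carbon bound to a double-bonded chain carbon. The two differ as follows: 4-nitrophenyl in place of 3-nitrophenyl on a double-bonded chain carbon bound to a double-bonded chain carbon and the shared core stays untouched.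

Among the compounds with values here, only one measured step bears on this change. It is a 5.1-fold higher number from compound 1 to compound 2 (0.71 log units; beyond the scatter) and it replaced 4-(dimethylamino)phenyl with 3-nitrophenyl, a modest step. That exchange swapped one substituent on the ring for a different one, whereas compound 3 keeps the nitrophenyl group of compound 2. Within the data shown here, no measured pair shows what such a swap alone does, so the earlier step serves only as a loose upper guide to size. The expected step is a 1.3-fold lower number from compound 2 to compound 3 (0.11 log units; within the scatter) in this assay and no clear direction is expected beyond the scatter. Compound 3 is estimated at 17000 nM with a range of 7000 nM to 40000 nM as the expected span.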

Compound 3, half-maximal inhibitory concentration: 9640 nM
Beside the measured number, compound 3's estimate is 1.8-fold (0.25 log units) above it; measured number inside the range.
By their numbers in this assay, from the lowest: compound 1; then compound 3; then compound 2.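

In this assay, moving the nitro group alone gives a 2.3-fold lower number from compound 2 to compound 3 (0.36 log units; beyond the scatter), so with the atoms unchanged, the choice between 3-nitrophenyl and 4-nitrophenyl on the double-bonded chain carbon already shifts the number beyond the scatter, which the earlier pair could not show. Compound 3 also separates the two changes combined in a 5.1-fold higher number from compound 1 to compound 2 (0.71 log units; beyond the scatter): with the substituent kept at the same ring position, nitro in place of dimethylamino on an aromatic carbon gives a 2.2-fold higher number from compound 1 to compound 3 (0.35 log units; beyond the scatter), so the exchange of substituent still counts beyond the scatter without any shift in position, and compound 1 keeps the lowest number of the three. No supporting data bear on what lies behind either step.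

Whether moving the substituent has a similar effect with dimethylamino as it has with nitro remains open, as the compounds shown offer only the nitro pair for that comparison. Also open, as far as these compounds go, is whether the lower number of compound 1 is particular to dimethylamino or would carry over to another ring substituent at that place, such as a methoxy group, a primary amine or a carboxylic acid.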